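Ring-nitrogen and aryl ether changes, cytotoxicity notes

A few compounds are considered here, and "the series" means these few. Any claim that something is new, unique, unknown or untested is made for them only; others in the source may bear on it.

Measured compounds:
Compound 1 `NC(=O)c1c(NC(=O)c2ccc(Oc3ccccc3)cc2)sc2c1CCN(C(=O)c1ccccc1)C2`: 4.71%
Compound 2 `CN1CCc2c(sc(NC(=O)c3ccc(Oc4ccccc4)cc3)c2C(N)=O)C1`: 58.9%
Compound 3 `CC(C)(C)OC(=O)N1CCc2c(sc(NC(=O)c3ccc(Oc4ccccc4)cc3)c2C(N)=O)C1`: 26.9%

In an ADME assay on RAW264.7 cells (Mus musculus) for cytotoxicity, read by MTT assay, with a stated time of 48 h, tested at 50 uM (a lower number here means less inhibition, a higher number more inhibition at the concentration tested (going by the name of the read-out)), compound 2 gives 58.9%, the highest of the three numbers. Compound 3 sits nearest to it, and compound 1 sits furthest, both differences beyond the scatter. The three measured steps all sit on the same part of the shared core: a number 54.2 percentage points higher from compound 1 to compound 2 (beyond the scatter) for methyl in place of benzoyl on an amine nitrogen in a ring; a number 22.2 percentage points higher from compound 1 to compound 3 (beyond the scatter) for tert-butoxy in place of phenyl on a carbonyl carbon; and a number 32 percentage points lower from compound 2 to compound 3 (beyond the scatter) for tert-butoxycarbonyl in place of methyl on an amine nitrogen in a ring. Every one of these changes the group on the ring nitrogen; none changes the aryl ether of the amide.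

Compound 4 `CN1CCc2c(sc(NC(=O)c3ccc(OCc4ccccc4)cc3)c2C(N)=O)C1` keeps the methyl on the ring nitrogen of compound 2 and differs from it only at the ether, phenoxy to benzyloxy:
benzyl in place of phenyl on an oxygen on an aromatic ring

Within the data shown here, no measured step bears on this change, so no direction can be read from the series, and the expected step is a number 3.9 percentage points lower from compound 2 to compound 4 (within the scatter), within the scatter. In this assay compound 4 is therefore estimated at 55%, with a range from 35% to 75%.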

Compound 4, a percentage reported as inhibition, at one concentration (the size of the read-out at that concentration, not a potency): 37.6%
Estimate against measurement, compound 4: 17.4 percentage points above, within the range that was stated.
By their numbers in this assay, from the lowest: compound 1; then compound 3; then compound 4; then compound 2.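

In this assay, the aryl ether now has a measured step of its own: a number 21.3 percentage points lower from compound 2 to compound 4 (beyond the scatter) for benzyl in place of phenyl on an oxygen on an aromatic ring. Among these compounds, the number therefore responds to this ether as well as to the group on the ring nitrogen, which was the only place the earlier steps covered. The two groups match in their aromatic ring, hydrogen-bond donors, hydrogen-bond acceptors and net charge, and go from 6 heavy atoms to 7, so a difference this small at the oxygen is enough to give a step beyond the scatter, though the data offer nothing that accounts for it.

Among the compounds shown, the phenoxy to benzyloxy change appears only with methyl on the ring nitrogen, so it remains open whether the step has the same direction and size with benzoyl or tert-butoxycarbonyl there. Also open, from the compounds shown here alone, is how this assay would read with a longer chain between the oxygen and the phenyl ring, such as phenylethyl, or with a small alkyl group such as ethyl on that oxygen in place of the aromatic group.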